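Lipophilicity notes on a quinoline ether amide series

The source may report more compounds than this note shows. Statements on the series, on what has been measured and on what is new or still open speak of the compounds shown alone.

Measured compounds and their values:
Compound 1 `CCOc1ccc2nc(C)cc(OCC(=O)Nc3cc(C)cc(C)c3)c2c1`: in a physicochemical assay for lipophilicity, read by HPLC, in phosphate buffer, measured as chromatographic lipophilicity, at pH 7.4 (a higher number here means a more lipophilic compound, a lower number a more polar compound), compound 1 gives 5.98.
Compound 2 `COc1ccc2nc(C)c(NC(=O)C(=O)Nc3cc(C)cc(C)c3)c(O)c2c1`: in this assay compound 2 gives 3.76.
Compound 3 `COc1cccc(NC(=O)COc2cc(C)nc3ccc(OC)cc23)c1`: in this assay compound 3 gives 4.49.

Compound 3 stands second highest of the three numbers, below compound 1 and above compound 2, and both gaps lie beyond the usual scatter. Compound 4 `COc1ccc2nc(C)cc(OCC(=O)Nc3cc(C)nc(C)n3)c2c1` has not been measured yet. It differs from compound 3 in a single place: 2,6-dimethylpyrimidin-4-yl in place of 3-methoxyphenyl on an amide-type nitrogen. Within the data shown here, no step between two measured compounds matches this change, so its size is not known from the series itself. In this assay a downward step is expected, beyond the scatter, estimated as a number 0.79 log units lower from compound 3 to compound 4 (beyond the scatter). For compound 4 the expected value is 3.7, with a range from 3.1 to 4.3.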

Compound 4, distribution coefficient: 3.24
Estimate against measurement, compound 4: 0.46 log units above, and the stated range covers the measured number.
By their numbers in this assay, from the lowest: compound 4; then compound 2; then compound 3; then compound 1.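

Among these compounds, the group on the amide-type nitrogen has a large bearing on the reading in this assay: the first single-place comparison gives a number 1.25 log units lower from compound 3 to compound 4 (beyond the scatter) with 2,6-dimethylpyrimidin-4-yl in place of 3-methoxyphenyl. The heavy-atom count of the group stays the same, so the step comes with an exchange of ring atoms and substituents, not with a change in group size. Nothing on hand accounts for this step. From the compounds shown here alone, whether the ring nitrogens or the two methyl groups carry the step stays open. Going by these compounds, how a pyridine ring or a phenyl ring bearing a carboxylic acid would read at this position also stays open.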